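Compound 2 to compound 3: replacing the 2-cyanoethyl group

This account rests on a few compounds, and the source may have more. Where it says the series, first, only, none or still open, it means among the compounds named here.

Measured so far in a physicochemical assay for solubility, with a stated time of 4 h, at pH 2.0; on this read-out lower numbers stand for lower solubility and higher numbers for higher solubility:
Compound 1 `Cc1cc(CCC#N)cc(C)c1Oc1cc(Nc2ccc(C#N)cc2)c(N)cc1CO` gives 89.8 ug/mL
Compound 2 `Cc1cc(CCC#N)cc(C)c1Oc1cc(Nc2ccc(C#N)cc2)c(N)cc1C(F)(F)F` gives 0.33 ug/mL

Among the compounds with values here, compound 2 holds the lower of the two numbers in this assay, and the gap to its only neighbour is large and beyond the scatter. Within the data shown here, the one measured step is a 270-fold lower number from compound 1 to compound 2 (2.43 log units; beyond the scatter), with trifluoromethyl in place of hydroxymethyl on an aromatic carbon.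

Compound 3 `Cc1cc(C#N)cc(C)c1Oc1cc(Nc2ccc(C#N)cc2)c(N)cc1C(F)(F)F` keeps that trifluoromethyl group and carries cyano in place of 2-cyanoethyl on an aromatic carbon. The measured step changes a different group, so it shows how far numbers can move in this series but offers no direct guide to the present change. Among the measured compounds shown here, no measured pair tests the 2-cyanoethyl group. The expectation therefore stays anchored on compound 2 at 0.33 ug/mL in this assay, with no step beyond the scatter expected in either direction. The estimated change is a 1.2-fold higher number from compound 2 to compound 3 (0.08 log units; within the scatter), a small one. For compound 3 the expected value is 0.4 ug/mL, with an estimated range of 0.1 ug/mL to 1.5 ug/mL.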

Compound 3, solubility: 0.96 ug/mL
Beside the measured number, compound 3's estimate is 2.4-fold (0.38 log units) below it; low and high end bracket the measured number.
By their numbers in this assay, from the lowest: compound 2; then compound 3; then compound 1.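

In this assay, cyano in place of 2-cyanoethyl on this aromatic carbon, para to a large group and meta to two methyl groups, gives a 2.9-fold higher number from compound 2 to compound 3 (0.46 log units; beyond the scatter), the first sign that the number responds to a change at this position. The step is modest beside a 270-fold lower number from compound 1 to compound 2 (2.43 log units; beyond the scatter), and the two groups it exchanges have much in common: each has one triple bond, one hydrogen-bond acceptor, no hydrogen-bond donors, no ring and no net charge, so the count of heavy atoms, 4 against 2, is what separates them in the listed terms. Nothing measured alongside this result accounts for the rise.

From the compounds shown here alone, with only these two groups compared at this position, a single step cannot establish any trend with chain size, and it remains open whether the same change would hold with hydroxymethyl in place of trifluoromethyl. Going by these compounds, it is also open how the number would move with an amine, a carboxylic acid or a longer chain on this carbon.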